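The source may hold more compounds than are shown below. What is called first, only, known or untested is meant among the compounds shown, and "the series" means these compounds.

In a functional assay on MDA-MB-468 cells (Homo sapiens) for antiproliferative activity, read by MTT assay, with a stated time of 24 h (on this read-out higher numbers stand for weaker inhibition and lower numbers for stronger inhibition), compound 1 `CNC(=O)c1ccccc1Oc1nc(Nc2ccc(Br)cc2)ncc1Br` gives 36600 nM, the only plain number shown so far. Compound 2 `CNC(=O)c1ccccc1Oc1nc(Nc2ccc(C(F)(F)F)cc2)ncc1Br` yields only a limit of the assay in this assay, > 50000 nM. Going by the values given here, the one measured step, an at least 1.3-fold higher number from compound 1 to compound 2 (0.13 log units; that floor lies within the scatter), changes a substituent on the ring that compound 3 `CNC(=O)c1ccccc1Oc1nc(Nc2ccccc2OC)ncc1Br` replaces entirely: 2-methoxyphenyl in place of 4-bromophenyl on a nitrogen on an aromatic ring. That step is small and rests on a limit, (the limit of > 50000 nM in this assay, at which 1 of the 2 values shown sits), so it offers little guidance, and no step beyond the scatter is expected here. Compound 3 is therefore estimated at 40000 nM, within a range of 15000 nM to 110000 nM. This expectation means a 1.1-fold higher number from compound 1 to compound 3 (0.04 log units; within the scatter).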

Compound 3, half-maximal inhibitory concentration: > 50000 nM
Compound 3: only a limit was reported (the forecaster's own chance of this, stated with the estimate: 40%); at least 1.2-fold (0.09 log units) between middle value and limit.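

In this assay the 2-methoxyphenyl group on the nitrogen gives an at least 1.3-fold higher number from compound 1 to compound 3 (0.13 log units; that floor lies within the scatter) and leaves only a limit, not a number. Compound 2 and compound 3 are two different replacements of 4-bromophenyl that now end at a limit, so they cannot be ranked against each other and only a floor is known for each against compound 1: (the limit of > 50000 nM in this assay, at which 2 of the 3 values shown sit).

Left open is whether an amine or a carboxylic acid on this ring would give a plain number, and whether any group here would fall clearly below compound 1 with its 36600 nM in this assay at all.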